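This account rests on a few compounds, and the source may have more. Where it says the series, first, only, none or still open, it means among the compounds named here.

Compound 3 `NCCCNc1cc(N2CCc3ccccc3C2)nc2ccccc12` carries an amine-bearing chain on the shared core. In an ADME assay on HEp-2 cells (Homo sapiens) for cytotoxicity, read by CCK-8 assay, with a stated time of 5 days (a higher number here means that more compound is tolerated, a lower number that less compound is tolerated), compound 3 gives 8400 nM, the lowest of the two numbers recorded, and compound 2 `OCC(O)CNc1cc(N2CCc3ccccc3C2)nc2ccccc12` gives 66000 nM. Compound 1 `Cc1ccc2nc(N3CCCc4ccc(F)cc4C3)cc(NCC3(N)COC3)c2c1` gives only a limit, > 100000 nM. Compound 4 `NCCCCNc1cc(N2CCc3ccccc3C2)nc2ccccc12` differs from compound 3 by aminomethyl in place of amino on a saturated chain carbon, three bonds along the chain from a nitrogen on an aromatic ring. Among the compounds with values here, the only measured step, a 7.9-fold lower number from compound 2 to compound 3 (0.90 log units; beyond the scatter), swaps a 1,2-dihydroxyethyl for a 2-aminoethyl on a saturated chain carbon bound to a nitrogen on an aromatic ring, whereas the move to compound 4 keeps the amino end and puts aminomethyl in place of amino, so that step bears on it only loosely. A step within the scatter is therefore expected in this assay. Compound 4 is expected at 8000 nM, between 3000 nM and 25000 nM, which would mean a 1.1-fold lower number from compound 3 to compound 4 (0.02 log units; within the scatter).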

Compound 4, half-maximal cytotoxic concentration: 7400 nM
Beside the measured number, compound 4's estimate is 1.1-fold (0.03 log units) above it; low and high end bracket the measured number.
By their numbers in this assay, from the lowest: compounds 4 and 3 (each within the scatter of the next); then compound 2. At a limit, above all of these: compound 1.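

In this assay, the 3-aminopropyl and 4-aminobutyl chains read alike (a 1.1-fold lower number from compound 3 to compound 4 (0.06 log units; within the scatter)), so at this place aminomethyl in place of amino is tolerated within the scatter. The second amine chain also stands clearly apart from the diol chain (an 8.9-fold lower number from compound 2 to compound 4 (0.95 log units; beyond the scatter)), as the first one did. Nothing shown gives a reason for either reading. The compounds shown leave open whether a still longer amine chain, a dimethylamino end or a carboxylic acid end at this place would give a different number.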